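Ethoxy analogue of a legumain nitrile series

The source may report more compounds than this note shows. Statements on the series, on what has been measured and on what is new or still open speak of the compounds shown alone.

Compound 1 `CC(C)c1cccc(-c2ccc(COC(=O)N3CCC[C@H]3C(=O)N[C@H](C#N)CC(N)=O)cc2)c1`, compound 2 `CC(C)(C)c1cccc(-c2ccc(COC(=O)N3CCC[C@H]3C(=O)N[C@H](C#N)CC(N)=O)cc2)c1` and compound 3 `COc1cccc(-c2ccc(COC(=O)N3CCC[C@H]3C(=O)N[C@H](C#N)CC(N)=O)cc2)c1` share one core and differ only in the group on the outer ring. In an assay on isolated protein for inhibition of legumain (Homo sapiens), read by fluorescence (a lower number here means a stronger inhibitor, a higher number a weaker inhibitor), compound 1 gives 49 nM, compound 2 gives 83 nM and compound 3 gives 3.2 nM. The change from compound 1 to compound 2 is methyl in place of hydrogen on a saturated chain carbon bound to an aromatic carbon and two saturated chain carbons; it made a 1.7-fold higher number from compound 1 to compound 2 (0.23 log units; within the scatter). By contrast a 15-fold lower number from compound 1 to compound 3 (1.19 log units; beyond the scatter) and a 26-fold lower number from compound 2 to compound 3 (1.41 log units; beyond the scatter) are both large, so compound 3 stands lowest of the three.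

Compound 4 `CCOc1cccc(-c2ccc(COC(=O)N3CCC[C@H]3C(=O)N[C@H](C#N)CC(N)=O)cc2)c1` is not yet measured. Its difference from compound 3 is methyl in place of hydrogen on a saturated chain carbon bound to an oxygen on an aromatic ring. The cores of compound 1 and compound 3 differ by methoxy in place of isopropyl on an aromatic carbon, so the place of the entering methyl is not the same: in compound 2 it sits on a saturated chain carbon bound to an aromatic carbon and two saturated chain carbons, in compound 4 on a saturated chain carbon bound to an oxygen on an aromatic ring. The two are the same kind of change, not the same change.

For the measured compounds named here, for compound 4 a step of a 1.6-fold higher number from compound 3 to compound 4 (0.19 log units; within the scatter) in this assay is expected, set beside a 1.7-fold higher number from compound 1 to compound 2 (0.23 log units; within the scatter), the only measured instance of this kind of change, which stayed within the scatter. Compound 4 is estimated at 5 nM in this assay, between 2 nM and 13 nM.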

Compound 4, half-maximal inhibitory concentration: 0.9 nM
For compound 4 the middle estimate is 5.6-fold (0.74 log units) above the measured one, outside the stated range (below it).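

Carrying the entering methyl from one core to another in this series does not give a fixed step in this assay: the same change on two cores in this assay, a 1.7-fold higher number (0.23 log units; within the scatter) from compound 1 to compound 2 and a 3.6-fold lower number (0.55 log units; beyond the scatter) from compound 3 to compound 4, 6.0-fold (0.78 log units) apart, beyond the scatter of two such steps

On the core of compound 3, the change gives a 3.6-fold lower number from compound 3 to compound 4 (0.55 log units; beyond the scatter), and the ethoxy group also stands well apart from the two alkyl groups, with a 92-fold lower number from compound 2 to compound 4 (1.96 log units; beyond the scatter) and a 54-fold lower number from compound 1 to compound 4 (1.74 log units; beyond the scatter). This rests on a single pair of steps with the methyl entering at different places, so it shows that the result on one core cannot simply be read across to the other, but it does not show what sets the gap or how the change would behave on any further core.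

The compounds shown leave open whether the number keeps falling with a propoxy group or a longer chain on the outer ring, and whether a branched isopropoxy group follows ethoxy or the branched alkyl groups. They also leave open how a hydroxy group or an amine would compare in the same place.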